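Same Chain Growth on a Second Core: Stability Expected Unchanged

This account rests on a few compounds, and the source may have more. Where it says the series, first, only, none or still open, it means among the compounds named here.

Compound 1, `CCCCCCCCCCNC(=O)Oc1ccc(Cl)cc1C(=O)Nc1cccc(Cl)c1`, gives 43 h in an ADME assay for metabolic stability, read by HPLC, at pH 7.4; a higher number here means that the compound lasts longer, a lower number that the compound disappears faster.
Compound 2, `CCCCCCCCCCCNC(=O)Oc1ccc(Cl)cc1C(=O)Nc1cccc(Cl)c1`, gives 43 h in this assay.
Compound 3, `CCCCCCCCCCNC(=O)Oc1ccc(Cl)cc1C(=O)Nc1ccc(Cl)cc1`, gives 43 h in this assay.

The three measured compounds sit at one level. Going from compound 1 to compound 2 the structural change is methyl in place of hydrogen on a saturated chain carbon, ten or more bonds along the chain from an amide-type nitrogen, and the step is no change at the digits printed from compound 1 to compound 2 (within the scatter). The two cores differ by 4-chlorophenyl in place of 3-chlorophenyl on an amide-type nitrogen, and that step is no change at the digits printed from compound 1 to compound 3 (within the scatter).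

Compound 4, `CCCCCCCCCCCNC(=O)Oc1ccc(Cl)cc1C(=O)Nc1ccc(Cl)cc1`, has not yet been measured. For the measured compounds named here, it differs from compound 3 by methyl in place of hydrogen on a saturated chain carbon, ten or more bonds along the chain from an amide-type nitrogen, which is the same change as the one from compound 1 to compound 2, made at a place described in the same words. The step from compound 3 to compound 4 in this assay is expected to be no change at the digits printed from compound 3 to compound 4 (within the scatter), about the size of the earlier one. This rests on compound 1 and compound 2, because no change at the digits printed from compound 1 to compound 2 (within the scatter) shows the added methyl left the half-life where it was, and on compound 3 standing level with both. For compound 4 the estimated value is 43 h, expected to lie between 25 h and 75 h.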

Compound 4, half-life: 43 h
Beside the measured number, compound 4's estimate shows no gap at the digits printed; the measured number falls inside the stated range.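

In this assay the new step is no change at the digits printed from compound 3 to compound 4 (within the scatter), so adding the methyl to the chain gave the same reading on the core of compound 3 as on the core of compound 1: the same change on two cores in this assay, no change at the digits printed (within the scatter) from compound 1 to compound 2 and no change at the digits printed (within the scatter) from compound 3 to compound 4, 1.0-fold (0.00 log units) apart, within the scatter of two such steps. The other new step, 4-chlorophenyl in place of 3-chlorophenyl with the longer chain in place, is no change at the digits printed from compound 2 to compound 4 (within the scatter), and this change also reads the same in both settings: the same change on two cores in this assay, no change at the digits printed (within the scatter) from compound 1 to compound 3 and no change at the digits printed (within the scatter) from compound 2 to compound 4, 1.0-fold (0.00 log units) apart, within the scatter of two such steps. This shows that, for these four compounds, each change left the half-life level on both cores, but it does not show how a change that moves the half-life beyond the scatter would carry from one core to another.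

The compounds shown leave open whether a much longer chain, or an amine or a carboxylic acid in place of the chain, would give a different reading in this assay. Also open, as far as these compounds go, is what a plain phenyl in place of the chlorophenyl would give.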